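The compounds below may be only part of what the source reports. "The series", "measured", "known", "first", "only" and "open" are said of these compounds alone.

Measured so far in an ADME assay on Karpas-1106P cells (Homo sapiens) for cytotoxicity; a higher number here means that more compound is needed for the effect, a lower number that less compound is needed:
- compound 1 `Cc1ccc(S(=O)(=O)N[C@@H](CC(=O)NC(C)(C)C)C(=O)NCCNC(=O)c2cccc(O)c2)cc1`; compound 1 gives > 11100 nM, a limit of the assay and not a number.
- compound 2 `COc1cccc(C(=O)NCCNC(=O)[C@H](CC(=O)NC(C)(C)C)NS(=O)(=O)c2ccc(C)cc2)c1`; compound 2 gives > 11100 nM, again a limit.
- compound 3 `Cc1ccc(S(=O)(=O)N[C@@H](CC(=O)NC(C)(C)C)C(=O)NCCNC(=O)c2cccc(F)c2)cc1`; compound 3 gives > 11100 nM, also a limit.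

Compound 1 therefore stands only at a limit in this assay, as do the other two. The three steps among them, a step that the two limits leave unreadable from compound 1 to compound 2, a step that the two limits leave unreadable from compound 1 to compound 3 and a step that the two limits leave unreadable from compound 2 to compound 3, carry no readable size, which follows from the limit of > 11100 nM in this assay, at which 3 of the 3 values shown sit.

Compound 4 `Cc1ccc(S(=O)(=O)N[C@@H](CC(=O)NC(C)(C)C)C(=O)NCCNC(=O)NCc2ccccc2)cc1` differs from compound 1 as follows: benzylamino in place of 3-hydroxyphenyl on a carbonyl carbon. Among the compounds with values here, none of the measured steps bears on this change; they all alter the substituent on the aromatic ring of the 3-hydroxyphenyl, whereas here that whole group gives way to benzylamino. With every measured value sitting at the limit, no direction can be read, and the expectation for compound 4 is simply a further limit, an expected step that the limit leaves unreadable from compound 1 to compound 4 with no readable size. Compound 4 is thus estimated at 15000 nM, within 7000 nM to 40000 nM, most probably reported as a limit only.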

Compound 4, half-maximal effective concentration: > 11100 nM
Compound 4: only a limit was reported (the forecaster's own chance of this, stated with the estimate: 80%); the middle value does not contradict the limit.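

In this assay compound 4 gives > 11100 nM, a limit of the assay and not a number. The steps from compound 1, compound 2 and compound 3 to compound 4 therefore cannot be read: the limit of > 11100 nM in this assay, at which 4 of the 4 values shown sit.

The compounds shown leave open whether any of these changes shifts the half-maximal effective concentration at all, and in which direction.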